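A few compounds are considered here, and "the series" means these few. Any claim that something is new, unique, unknown or untested is made for them only; others in the source may bear on it.

Three compounds have been measured in an ADME assay on A549 cells (Homo sapiens) for cytotoxicity, read by MTT assay, with a stated time of 72 h; a higher number here means a weaker inhibitor, a lower number a stronger inhibitor:

compound 1, `O=C1Nc2ccc([N+](=O)[O-])cc2/C1=C/c1ccco1`: 329000 nM
compound 2, `O=C1Nc2ccc(Br)cc2C1=Cc1cccs1`: 427000 nM
compound 3, `COC(=O)Nc1ccc2c(c1)/C(=C/c1ccc(Br)cc1)C(=O)N2`: > 100000 nM

For compound 3 the value is a limit of this assay, not a number, as the limit of > 100000 nM in this assay, at which 1 of the 3 values shown sits, states. Among the two numbers, compound 2 has the higher one, but its gap to compound 1 is within the usual scatter, so the two compounds stand together.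

Compound 4, `O=C1Nc2ccc(Br)cc2C1=Cc1ccncc1`, has not yet been measured in this assay. It differs from compound 2 in one place: pyridin-4-yl in place of thiophen-2-yl on a double-bonded chain carbon bound to a double-bonded ring carbon. Among the compounds with values here, no pair of measured compounds differing in one place is available, so no measured step can be drawn on. Since the number for compound 2 is 427000 nM and compound 1 sits with it, the account expects the step of a 1.1-fold lower number from compound 2 to compound 4 (0.03 log units; within the scatter) to stay within the scatter, in no particular direction. Compound 4 is therefore estimated at 400000 nM, with a range from 150000 nM to 1000000 nM.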

Compound 4, half-maximal inhibitory concentration: 22300 nM
For compound 4 the middle estimate is 18-fold (1.25 log units) above the measured one; the measured number lies below the stated range.
By their numbers in this assay, from the lowest: compound 4; then compounds 1 and 2 (each within the scatter of the next).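

In this assay, pyridin-4-yl in place of thiophen-2-yl on a double-bonded chain carbon bound to a double-bonded ring carbon gives a 19-fold lower number from compound 2 to compound 4 (1.28 log units; beyond the scatter), so the number does respond to a change at this position. Within the data shown here, the earlier compounds offered no pair differing in one place, so this is the first reading of any single change. The two groups have the same counts of hydrogen-bond donors and acceptors and no net charge, differing in ring size and hetero atom, and nothing shown here gives a cause for the step.

As far as these compounds go, whether the step follows the ring nitrogen or the ring size stays open; a plain phenyl ring or pyridin-3-yl at the same place would separate the two. Compound 3 gives > 100000 nM, which is a limit of the assay and not a number, so it adds nothing to this question.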